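This account rests on a few compounds, and the source may have more. Where it says the series, first, only, none or still open, it means among the compounds named here.

Within the data shown here, compound 2 `CSc1cc(C)nc(NC(=S)NC(=O)c2c(-c3ccc(Cl)cc3Cl)noc2C)n1` gives 45.5% in a functional assay on the whole organism for inhibition, with Digitaria ciliaris as the target, with a stated time of 72 h, tested at 100 mg/L; on this read-out higher numbers stand for more inhibition of growth at the one concentration tested and lower numbers for less inhibition of growth; it is one of only two numbers measured so far, the other being compound 1 `Cc1cc(O)nc(NC(=S)NC(=O)c2c(-c3ccc(Cl)cc3Cl)noc2C)n1`, which gives 49.3% in this assay. Among the measured compounds shown here, the single measured step, a number 3.8 percentage points lower from compound 1 to compound 2 (within the scatter), was small. Compound 3 `COc1cc(OC)nc(NC(=S)NC(=O)c2c(-c3ccc(Cl)cc3Cl)noc2C)n1` differs from compound 2 by 4,6-dimethoxypyrimidin-2-yl in place of 4-methyl-6-(methylsulfanyl)pyrimidin-2-yl on an amide-type nitrogen. For the measured compounds named here, only that one step, also a change on the same ring, bears on it, and it stayed within the scatter, so the expected step of a number 1.5 percentage points higher from compound 2 to compound 3 (within the scatter) is none beyond the scatter in this assay. For compound 3 the estimate in this assay is 47%, with a range from 25% to 70%.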

Compound 3, percent growth inhibition at one concentration: 65.9%
Estimate against measurement, compound 3: 18.9 percentage points below, within the range that was stated.
By their numbers in this assay, from the lowest: compounds 2 and 1 (each within the scatter of the next); then compound 3.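

Among these compounds, on an amide-type nitrogen, 4,6-dimethoxypyrimidin-2-yl gives the first steps beyond the scatter in this assay: a number 20.4 percentage points higher from compound 2 to compound 3 (beyond the scatter) and a number 16.6 percentage points higher from compound 1 to compound 3 (beyond the scatter). The step from compound 1 to compound 2 stayed within the scatter, so only compound 3 shows that changing the groups on this ring can shift growth inhibition. Nothing available explains this gain. Still open, on these data alone, is whether a single methoxy group alongside methyl carries the same gain. Also open, as far as these compounds go, is how an amine or ethoxy in place of methoxy would read.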